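This account rests on a few compounds, and the source may have more. Where it says the series, first, only, none or still open, it means among the compounds named here.

Of the compounds shown here, three sharing one core have been tested in an ADME assay on BJ cells (Homo sapiens), read by MTT assay, with a stated time of 72 h; a lower number here means a stronger inhibitor, a higher number a weaker inhibitor. Compound 2 `COc1ncnc2c1c(-c1ccoc1)cn2[C@@H]1O[C@H](CO)[C@@H](O)[C@H]1O` gives 28800 nM, the lowest of the three numbers. Compound 1 `COc1ncnc2c1c(-c1ccsc1)cn2[C@@H]1O[C@H](CO)[C@@H](O)[C@H]1O` gives 64300 nM, and compound 3 `CN(C)c1ncnc2c1c(-c1ccoc1)cn2[C@@H]1O[C@H](CO)[C@@H](O)[C@H]1O` gives 99200 nM. Two single changes connect them. Replacing thiophen-3-yl with furan-3-yl on an aromatic carbon gives a 2.2-fold lower number from compound 1 to compound 2 (0.35 log units; beyond the scatter). Replacing methoxy with dimethylamino on an aromatic carbon gives a 3.4-fold higher number from compound 2 to compound 3 (0.54 log units; beyond the scatter). Both steps lie beyond the scatter, so compound 2 stands clearly apart from the other two in this assay.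

Compound 4 `COc1ncnc2c1c(-c1cccs1)cn2[C@@H]1O[C@H](CO)[C@@H](O)[C@H]1O` is not yet measured. It differs from compound 2 in one place: thiophen-2-yl in place of furan-3-yl on an aromatic carbon. Within the data shown here, only one measured step touches this kind of change, the swap of thiophen-3-yl for furan-3-yl, which gave a 2.2-fold lower number from compound 1 to compound 2 (0.35 log units; beyond the scatter). Read backwards, going from a furan ring to a thiophene ring raised the number by a modest amount. Compound 4 carries thiophen-2-yl rather than thiophen-3-yl, so that step is a guide rather than a copy. A modest rise is therefore expected, of a size close to that step. For compound 4 the estimated value is 55000 nM, with a range from 22000 nM to 140000 nM. This expectation corresponds to a 1.9-fold higher number from compound 2 to compound 4 (0.28 log units; within the scatter).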

Compound 4, half-maximal inhibitory concentration: 62800 nM
Compound 4: middle estimate off by 1.1-fold (0.06 log units), on the low side, within the range that was stated.
By their numbers in this assay, from the lowest: compound 2; then compounds 4, 1 and 3 (each within the scatter of the next).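

In this assay, the step of a 1.0-fold lower number from compound 1 to compound 4 (0.01 log units; within the scatter) shows that thiophen-2-yl and thiophen-3-yl cannot be told apart at this place on the core, as the difference lies within the scatter. The step of a 2.2-fold higher number from compound 2 to compound 4 (0.34 log units; beyond the scatter) lies beyond the scatter and is similar in size to a 2.2-fold lower number from compound 1 to compound 2 (0.35 log units; beyond the scatter), so compound 2, with furan-3-yl, keeps a lower number than either thiophene compound, whichever way the thiophene ring is attached. Nothing measured here accounts for this gap between the furan and thiophene compounds.

The compounds shown leave open whether furan-2-yl would match furan-3-yl, or whether the furan result depends on how that ring is attached, as it does not for the two thiophene compounds. They also leave open how a six-membered ring such as phenyl or pyridinyl would compare at this place, and whether the dimethylamino group of compound 3 would raise the number in the same way when paired with thiophen-2-yl instead of furan-3-yl.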